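From 2,4-dimethylphenyl to 3,5-dichlorophenyl in compound 3

A few compounds are considered here, and "the series" means these few. Any claim that something is new, unique, unknown or untested is made for them only; others in the source may bear on it.

Compound 1 `Cc1ccc(CNC(=O)C(=O)N[C@@H](C)C(=O)N[C@@H](CC(=O)O)C(=O)COc2c(F)c(F)cc(F)c2F)cc1`: 50 nM
Compound 2 `C[C@H](NC(=O)C(=O)NCc1cccc(F)c1)C(=O)N[C@@H](CC(=O)O)C(=O)COc1c(F)c(F)cc(F)c1F`: 106 nM
Compound 3 `Cc1ccc(CNC(=O)C(=O)N[C@@H](C)C(=O)N[C@@H](CC(=O)O)C(=O)COc2c(F)c(F)cc(F)c2F)c(C)c1`: > 10000 nM (a limit)

All three values come from a functional assay on Jurkat cells (Homo sapiens) (on this read-out lower numbers stand for stronger inhibition and higher numbers for weaker inhibition), and share one core. Compound 3 gives only a limit (> 10000 nM), so it has no exact number, and the steps that reach it are minimum sizes.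

The next structure is compound 4 `C[C@H](NC(=O)C(=O)NCc1cc(Cl)cc(Cl)c1)C(=O)N[C@@H](CC(=O)O)C(=O)COc1c(F)c(F)cc(F)c1F`, which puts 3,5-dichlorophenyl in place of 2,4-dimethylphenyl on a saturated chain carbon bound to an amide-type nitrogen.

Among the compounds with values here, three measured steps bear on this change. Adding one methyl on an aromatic carbon gave an at least 200-fold higher number from compound 1 to compound 3 (2.30 log units; beyond the scatter), a large step. Replacing 3-fluorophenyl with 2,4-dimethylphenyl gave an at least 94-fold higher number from compound 2 to compound 3 (1.97 log units; beyond the scatter), also large. Exchanging 4-methylphenyl for 3-fluorophenyl gave only a 2.1-fold higher number from compound 1 to compound 2 (0.33 log units; beyond the scatter), a modest step, though beyond the scatter. So two quite different groups sit close together, and only compound 3 falls away. Compound 4 no longer carries the 2,4-dimethylphenyl group, so it is expected to sit nearer compound 1 and compound 2. Within the data shown here, no measured compound contains chlorine, which keeps the range wide.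

The expected change is an at least 83-fold lower number from compound 3 to compound 4 (1.92 log units; beyond the scatter), a large estimated step towards stronger inhibition. Compound 4 is estimated at 120 nM (expected range 25 nM to 1500 nM).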

Compound 4, half-maximal inhibitory concentration: 23 nM
For compound 4 the middle estimate is 5.2-fold (0.72 log units) above the measured one; the measured number lies below the stated range.
By their numbers in this assay, from the lowest: compound 4; then compound 1; then compound 2. At a limit, above all of these: compound 3.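

In this assay, 3,5-dichlorophenyl in place of 2,4-dimethylphenyl on a saturated chain carbon bound to an amide-type nitrogen gives an at least 430-fold lower number from compound 3 to compound 4 (2.63 log units; beyond the scatter), so carrying two groups on the ring does not by itself ruin inhibition at this position. That size is only a minimum, since compound 3 stands at a limit of the assay and not at an exact number: the limit of > 10000 nM in this assay, at which 1 of the 4 values shown sits. Compound 4 also improves on the two compounds with one group on the ring, with a 4.6-fold lower number from compound 2 to compound 4 (0.66 log units; beyond the scatter) and a 2.2-fold lower number from compound 1 to compound 4 (0.34 log units; beyond the scatter), both modest steps but beyond the scatter, which makes it the strongest inhibitor of the four shown.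

Going by these compounds, what remains open is whether the collapse in compound 3 depends on where the groups sit on the ring or on what those groups are, a question that 2,4-dichlorophenyl and 3,5-dimethylphenyl would separate. It is also open how far this position tolerates a ring bearing an amine or a carboxylic acid, since every ring shown here carries only methyl or halogen groups.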